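The compounds below may be only part of what the source reports. "The series", "measured", "known", "first", "only" and "open" are said of these compounds alone.

Measured in an assay on microsomes from brain for inhibition of Fatty-acid amide hydrolase 1 (Rattus norvegicus), read by fluorescence and HPLC, with a stated time of 60 min; on this read-out lower numbers stand for stronger inhibition and higher numbers for weaker inhibition:
compound 1 `CCCCCCCCc1ccc(OCC(=O)Cn2nnc(SC)n2)cc1` gives 31 nM
compound 2 `CCCCCCCCc1ccc(OCC(=O)Cn2nnc(-c3ccc(S(=O)(=O)N(C)C)cc3)n2)cc1` gives 590 nM
compound 3 `CCCCCCCCc1ccc(OCC(=O)Cn2nnc(C(=O)OC)n2)cc1` gives 88 nM

Compound 3 stands second highest of the three numbers: a 2.8-fold higher number from compound 1 to compound 3 (0.45 log units; beyond the scatter) sets it apart from compound 1, and a 6.7-fold lower number from compound 2 to compound 3 (0.83 log units; beyond the scatter) from compound 2. Compound 4 `CCCCCCCCc1ccc(OCC(=O)Cn2nnnc2SC)cc1` differs from compound 3 by 5-(methylsulfanyl)-1H-tetrazol-1-yl in place of 5-(methoxycarbonyl)-2H-tetrazol-2-yl on a saturated chain carbon bound to a carbonyl carbon. Within the data shown here, the only measured step that bears on this change is a 2.8-fold higher number from compound 1 to compound 3 (0.45 log units; beyond the scatter), run in reverse, since compound 4 carries the methylsulfanyl group of compound 1; the move from 2H-tetrazol-2-yl to 1H-tetrazol-1-yl has no measured counterpart. A modest step downward in this assay is therefore expected, a 1.8-fold lower number from compound 3 to compound 4 (0.25 log units; within the scatter), with added uncertainty from the unmatched part of the change. Compound 4 is estimated at 50 nM (range 15 nM to 200 nM).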

Compound 4, half-maximal inhibitory concentration: 22 nM
For compound 4 the middle estimate is 2.3-fold (0.36 log units) above the measured one; the measured number falls inside the stated range.
By their numbers in this assay, from the lowest: compounds 4 and 1 (each within the scatter of the next); then compound 3; then compound 2.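

In this assay, 5-(methylsulfanyl)-1H-tetrazol-1-yl in place of 5-(methylsulfanyl)-2H-tetrazol-2-yl gives a 1.4-fold lower number from compound 1 to compound 4 (0.15 log units; within the scatter), so this read-out does not separate the two tetrazole attachments when they carry methylsulfanyl. The step of a 4.0-fold lower number from compound 3 to compound 4 (0.60 log units; beyond the scatter) combines that change of attachment with the exchange of methoxycarbonyl for methylsulfanyl. No supporting data bear on the reason for either step.

Going by these compounds, whether the attachments also match when they carry methoxycarbonyl or 4-(dimethylsulfamoyl)phenyl remains open. So does the effect of a carboxylic acid or an amine in place of methylsulfanyl.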